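Replacing the cyclohexyl ring on the urea nitrogen

A few compounds are considered here, and "the series" means these few. Any claim that something is new, unique, unknown or untested is made for them only; others in the source may bear on it.

Of the compounds shown here, three built on one shared core have so far been tested in a functional assay on the whole organism (blood) with Rattus norvegicus as the target, with stated times of 24 h and 1 h, at a dose of 5 mg/kg by the intraperitoneal route; a higher number here means a stronger effect of the compound at the dose given, a lower number a weaker effect. Compound 1 `O=C(NC1CCCCC1)NS(=O)(=O)N1CCC(CCNC(=O)c2csnn2)CC1` gives 19% in this assay. Compound 2 `COc1ncccc1C(=O)NCCC1CCN(S(=O)(=O)NC(=O)NC2CCCCC2)CC1` gives 33% in this assay. Compound 3 `O=C(NC1CCCCC1)NS(=O)(=O)N1CCC(CCNC(=O)c2cc(Cl)cc3cccnc23)CC1` gives 52% in this assay. Compound 2 thus stands second highest of the three numbers: the step of a number 14 percentage points higher from compound 1 to compound 2 (beyond the scatter) lies beyond the scatter, as does the step of a number 19 percentage points higher from compound 2 to compound 3 (beyond the scatter), and the largest step is a number 33 percentage points higher from compound 1 to compound 3 (beyond the scatter).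

All three of these steps exchange the group on the carbonyl carbon. Compound 4 `COc1ncccc1C(=O)NCCC1CCN(S(=O)(=O)NC(=O)NC[C@H]2C[C@@H]3CC[C@@H]2O3)CC1` differs from compound 2 at another place: a group of 8 heavy atoms (7 carbon, 1 oxygen; 2 five-membered non-aromatic rings with 1 hetero atom each) in place of a group of 6 heavy atoms (6 carbon; one six-membered non-aromatic ring of carbon only), on an amide-type nitrogen. Going by the values given here, no measured step touches this position, so none of them bears directly on the change; they show only that the group on the carbonyl carbon can move the number by modest to large amounts, while the urea nitrogen has so far carried cyclohexyl in every compound. With no evidence at this site, the step is expected to be no change at the digits printed from compound 2 to compound 4 (within the scatter), that is, none beyond the scatter, with wide uncertainty. Compound 4 is therefore estimated to give 33% in this assay, within a range from 15% to 50%.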

Compound 4, a percentage reported as activity, at one dose (the size of the read-out at that dose, not a potency): 14%
Estimate against measurement, compound 4: 19 percentage points above, and the stated range ends above it.
By their numbers in this assay, from the lowest: compounds 4 and 1 (each within the scatter of the next); then compound 2; then compound 3.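

The urea nitrogen turns out not to be a silent position: in this assay, putting the group of 8 heavy atoms, with its 2 five-membered non-aromatic rings, in place of cyclohexyl gives a number 19 percentage points lower from compound 2 to compound 4 (beyond the scatter). The earlier compounds shown here all carried cyclohexyl here and could say nothing about this site, whereas this pair shows that a change on the amide-type nitrogen can move the number by a modest step, just as changes on the carbonyl carbon can. Whether the ring oxygen, the extra heavy atoms or the 3 defined stereocentres of the new group account for the drop cannot be told from one pair, and no measurement at hand speaks to the cause.

The compounds shown place only two groups on this nitrogen, so it remains open how a cyclopentyl ring, a phenyl ring or a cyclohexylmethyl group would read there. Also open, as far as these compounds go, is whether the same exchange would lower the number when the carbonyl carbon carries 6-chloroquinolin-8-yl or 1,2,3-thiadiazol-4-yl rather than 2-methoxypyridin-3-yl.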